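Aryl urea series: chloro removed from the terminal ring

The source may hold more compounds than are shown below. What is called first, only, known or untested is meant among the compounds shown, and "the series" means these compounds.

Compound 1 `O=C(Nc1cccc(-n2cc(-c3ccncc3)c(-c3cc(O)cc(Cl)c3)n2)c1)Nc1ccc(Cl)c(C(F)(F)F)c1` gives 88% in a functional assay on RPMI-8226 cells (Homo sapiens) for inhibition, read by sulforhodamine B assay, with a stated time of 48 h, tested at 1 uM; a lower number here means a stronger effect, a higher number a weaker effect of the compound at the concentration tested. Going by the values given here, compound 2 `COc1cc(Cl)cc(-c2nn(-c3cccc(NC(=O)Nc4ccc(Cl)c(C(F)(F)F)c4)c3)cc2-c2ccncc2)c1` gives 17% in this assay, the lowest of the two numbers; the only measured step is a number 71 percentage points lower from compound 1 to compound 2 (beyond the scatter). Compound 3 `COc1cc(Cl)cc(-c2nn(-c3cccc(NC(=O)Nc4cccc(C(F)(F)F)c4)c3)cc2-c2ccncc2)c1` differs from compound 2 by hydrogen in place of chloro on an aromatic carbon, the (4-chloro-3-(trifluoromethyl)phenyl)amino end becoming (3-(trifluoromethyl)phenyl)amino. Among the compounds with values here, no measured step concerns this place, and the step on the oxygen does not bear on it. Without such a guide, a moderate weakening is expected, an upward step of a number 18 percentage points higher from compound 2 to compound 3 (beyond the scatter). Compound 3 is estimated at 35%, within 12% to 65%.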

Compound 3, a percentage reported as activity, at one concentration (the size of the read-out at that concentration, not a potency): 22%
Beside the measured number, compound 3's estimate is 13 percentage points above it, and the stated range covers the measured number.
By their numbers in this assay, from the lowest: compounds 2 and 3 (each within the scatter of the next); then compound 1.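

In this assay, hydrogen in place of chloro, para to a large group and ortho to a trifluoromethyl group, gives a number 5 percentage points higher from compound 2 to compound 3 (within the scatter) and so leaves the read-out at the tested concentration within the scatter. For this pair, the chloro of the 4-chloro-3-(trifluoromethyl)phenyl end is therefore not needed to keep that read-out. No measurement bears on why this is so.

Open, as far as these compounds go, is whether a methoxy or an amine at this place would give the same read-out. A single concentration also leaves any potency difference between compound 2 and compound 3 unresolved.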